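A few compounds are considered here, and "the series" means these few. Any claim that something is new, unique, unknown or untested is made for them only; others in the source may bear on it.

Working notes on the series, read in a functional assay; on this read-out lower numbers stand for stronger inhibition and higher numbers for weaker inhibition. Compound 1 (`Oc1cc(/C=C/c2cc(O)c(O)c(O)c2)cc(O)c1O`) gives 0.9 ug/mL, and compound 2 (`Oc1cc(/C=C/c2cc(O)c(O)c(Br)c2)cc(O)c1O`) gives 8.1 ug/mL. Compound 3 (`O=C(c1cc(O)cc(/C=C/c2ccc(O)cc2)c1)c1cc(O)c(O)c(O)c1`) gives 16 ug/mL, within the scatter of compound 2 and on the weaker side of compound 1, beyond the scatter. Compound 4 (`O=C(c1cc(/C=C/c2ccc(O)cc2)cc(C(=O)c2cc(O)c(O)c(O)c2)c1)c1cc(O)c(O)c(O)c1`) differs from compound 3 by one change: (3,4,5-trihydroxyphenyl)carbonyl in place of hydroxy on an aromatic carbon.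

Among the compounds with values here, only one measured step bears on this change, and only indirectly. Bromo in place of hydroxy on an aromatic carbon gives a 9.0-fold higher number from compound 1 to compound 2 (0.95 log units; beyond the scatter), a modest step in which a hydroxy is lost and the number rises. Within the data shown here, the step to compound 4 also loses a hydroxy, but it brings in a further (3,4,5-trihydroxyphenyl)carbonyl, and no measured step adds such a group. On that thin evidence, a modest move towards a lower number is expected, and the expected step is a 2.3-fold lower number from compound 3 to compound 4 (0.36 log units; beyond the scatter). The estimate for compound 4 is 7 ug/mL, with an expected range of 2 ug/mL to 22 ug/mL.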

Compound 4, half-maximal inhibitory concentration: 17.5 ug/mL
The estimate for compound 4 lay 2.5-fold (0.40 log units) below the measured number; the range from low to high includes it.
By their numbers in this assay, from the lowest: compound 1; then compounds 2, 3 and 4 (each within the scatter of the next, the first and the last beyond it).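

In this assay, (3,4,5-trihydroxyphenyl)carbonyl in place of hydroxy at this position, meta to a 2-(4-hydroxyphenyl)ethenyl group, gives a 1.1-fold higher number from compound 3 to compound 4 (0.04 log units; within the scatter), so compound 3 and compound 4 cannot be told apart on this read-out. The position therefore accepts a second such group, with its added aromatic ring and hydrogen-bond donors, without a step beyond the scatter. The loss of a hydroxy here does not repeat the earlier 9.0-fold higher number from compound 1 to compound 2 (0.95 log units; beyond the scatter), although that step lies at a different place and brings in bromo, and no information at hand accounts for the difference.

Still open, as far as these compounds go, is whether a smaller group at this position, such as methoxy, an amine or a carboxylic acid, would separate from compound 3 beyond the scatter. Also open, from the compounds shown here alone, is whether the three hydroxy groups of the entering group matter, which an unsubstituted benzoyl group would test.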